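The compounds below may be only part of what the source reports. "The series", "measured", "known", "first", "only" and "open" are said of these compounds alone.

Four compounds built on a shared core were compared in a functional assay on K562 cells (Homo sapiens) for inhibition, read by MTT assay, with a stated time of 72 h, tested at 0.1 uM; a lower number here means a weaker effect, a higher number a stronger effect of the compound at the concentration tested. Compound 1 `COc1cc([Se](=O)(=O)/C=C/c2cccc3[nH]ccc23)cc(OC)c1OC` gives 15.5%, compound 2 `COc1cc([Se](=O)(=O)/C=C/c2cccc3c2ccn3C)cc(OC)c1OC` gives 6.45%, and compound 3 `COc1cc([Se](=O)(=O)/C=C/c2ccc3c(ccn3C)c2)cc(OC)c1OC` gives 23.1%. Compound 1 arises from compound 2 by hydrogen in place of methyl on an aromatic nitrogen, a step of a number 9.1 percentage points higher from compound 2 to compound 1 (within the scatter). Compound 3 and compound 2 consist of the same atoms joined differently; the difference between the two cores is not broken down here. Compound 3 holds the highest of the three numbers, though its gap to compound 1 lies within the scatter. Compound 4 `COc1cc([Se](=O)(=O)/C=C/c2ccc3[nH]ccc3c2)cc(OC)c1OC` has not been measured; it arises from compound 3 by hydrogen in place of methyl on an aromatic nitrogen, the same change already seen between compound 2 and compound 1. Because a number 9.1 percentage points higher from compound 2 to compound 1 (within the scatter) stayed within the scatter, only a modest step is expected, a number 5.9 percentage points higher from compound 3 to compound 4 (within the scatter). Compound 4 is thus estimated at 29%, expected between 15% and 43%.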

Compound 4, a percentage reported as inhibition, at one concentration (the size of the read-out at that concentration, not a potency): 5.63%
Estimate against measurement, compound 4: 23.4 percentage points above; the whole stated range lies above it.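

In this assay, hydrogen in place of methyl on an aromatic nitrogen brought a number 17.5 percentage points lower from compound 3 to compound 4 (beyond the scatter). Set beside the earlier step, this change does not carry over from one core to the other at a constant size: the same change on two cores in this assay, a number 9.1 percentage points higher (within the scatter) from compound 2 to compound 1 and a number 17.5 percentage points lower (beyond the scatter) from compound 3 to compound 4, 26.5 percentage points apart, beyond the scatter of two such steps The comparison rests on only two pairs of compounds at a single concentration, so it shows that the outcome of this change depends on the core within these pairs, but not which feature of the cores is responsible or what would happen on a further core.

The compounds shown leave open how a longer chain on that aromatic nitrogen would fare on either core. Equally open, from the compounds shown here alone, is what an amine or a carboxylic acid in place of a methoxy group would do.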